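Replacing the methylcarbamoyl group of compound 2

The source may hold more compounds than are shown below. What is called first, only, known or untested is meant among the compounds shown, and "the series" means these compounds.

Measured in an ADME assay (liver) for metabolic stability, with Liver microsome (Rattus norvegicus) as the target, using microsomes and NADPH, with a stated time of 30 min; on this read-out higher numbers stand for fast clearance and lower numbers for slow clearance:
- Compound 1 `CC#C[C@H]1CN(S(=O)(=O)c2ccc(N)nc2)CCN1c1ccc(S(=O)(=O)NCC2CC2)cc1` gives 213 mL.min-1.g-1
- Compound 2 `CC#C[C@H]1CN(S(=O)(=O)c2ccc(N)nc2)CCN1c1ccc(C(=O)NC)cc1` gives 41 mL.min-1.g-1

Of these two, compound 2 has the lower number in this assay, at 41 mL.min-1.g-1, and the gap to the other compound lies beyond the scatter. Compound 3 `CC#C[C@H]1CN(S(=O)(=O)c2ccc(N)nc2)CCN1c1ccc([C@](O)(CO)C(F)(F)F)cc1` is the next case, and its structural change is 1,2-dihydroxy-1-(trifluoromethyl)ethyl in place of methylcarbamoyl on an aromatic carbon. Among the measured compounds shown here, only one measured step bears on this change, a modest one at the same aromatic carbon: a 5.2-fold lower number from compound 1 to compound 2 (0.72 log units; beyond the scatter). That step does not involve the entering 1,2-dihydroxy-1-(trifluoromethyl)ethyl group, so the data set no direction for it. No shift beyond the scatter is therefore expected in this assay, though the uncertainty is wide. The estimated change is a 1.2-fold higher number from compound 2 to compound 3 (0.09 log units; within the scatter). For compound 3 the expected value is 50 mL.min-1.g-1, with an estimated range of 18 mL.min-1.g-1 to 140 mL.min-1.g-1.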

Compound 3, intrinsic clearance in microsomes: < 14 mL.min-1.g-1
Compound 3: only a limit was reported; the forecaster's own chance of this, stated with the estimate: 8%; middle value at least 3.5-fold (0.55 log units) from the limit.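

The aromatic carbon para to a large group still has room for change after methylcarbamoyl: in this assay, 1,2-dihydroxy-1-(trifluoromethyl)ethyl gives an at least 2.9-fold lower number from compound 2 to compound 3 (0.46 log units; beyond the scatter). Measured against (cyclopropylmethyl)sulfamoyl, the same group gives an at least 15-fold lower number from compound 1 to compound 3 (1.18 log units; beyond the scatter), so this one position alone spans a large range in clearance while the rest of the molecule stays the same. Compound 3 is reported only as a limit, not as a number: the limit of < 14 mL.min-1.g-1 in this assay, at which 1 of the 3 values shown sits.

Going by these compounds, how far compound 3 truly lies from the other two therefore stays open, and both steps give only a minimum size. Also open, on these data alone, is which part of the entering group goes with the drop, and how a simple hydroxymethyl, a carboxylic acid or an amine at this carbon would read, as well as the opposite configuration at the stereocentre.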